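Removing the propanoyl ester from compound 1

The source may report more compounds than this note shows. Statements on the series, on what has been measured and on what is new or still open speak of the compounds shown alone.

Compound 1 `CCOC(=O)C1=C(S[C@@H]2CN[C@H](C(=O)Nc3cccc(C(=O)OCC)c3)C2)[C@H](C)[C@@H]2[C@@H]([C@@H](C)OC(=O)CC)C(=O)N12`: 20.2%
Compound 2 `CC(C)C(=O)OCOC(=O)C1=C(S[C@@H]2CN[C@H](C(=O)Nc3cccc(C(=O)OCOC(=O)C(C)C)c3)C2)[C@H](C)[C@@H]2[C@@H]([C@@H](C)O)C(=O)N12`: 3.6%
Compound 3 `C[C@@H](O)[C@H]1C(=O)N2C3=C(S[C@@H]4CN[C@@H](C4)C(=O)Nc4cccc(c4)C(=O)OCc4oc(=O)oc4COC3=O)[C@H](C)[C@H]12`: 1%

All three numbers come from an ADME assay on the whole organism (strain Beagle) for pharmacokinetics, with Canis familiaris (Canis lupus familiaris) as the target, read by LC-MS, at a dose of 10 mg/kg; on this read-out higher numbers stand for higher oral bioavailability and lower numbers for lower oral bioavailability. Compound 1 gives 20.2%, the highest of the three; compound 2 lies lower by more than the usual scatter, and compound 3 lower still. Compound 4 `CCOC(=O)C1=C(S[C@@H]2CN[C@H](C(=O)Nc3cccc(C(=O)OCC)c3)C2)[C@H](C)[C@@H]2[C@@H]([C@@H](C)O)C(=O)N12` has not yet been measured. It differs from compound 1 in a single place: hydrogen in place of propanoyl on an oxygen on a saturated carbon. Among the compounds with values here, no pair of measured compounds differs by this change alone, so its size cannot be read off directly. Compounds 2 and 3 also carry the hydroxy group, but each differs from compound 1 elsewhere as well, so their low numbers are only a loose pointer. Still, compound 4 is expected to fall below compound 1, with a step of a number 13.2 percentage points lower from compound 1 to compound 4 (beyond the scatter) beyond the scatter. This expectation rests on compound 2, which gives 3.6%, and on compound 3, which gives 1%. The estimate for compound 4 is 7%, with a range from 1.5% to 18%.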

Compound 4, oral bioavailability: 31.3%
The estimate for compound 4 lay 24.3 percentage points below the measured number; measured number above the stated range.
By their numbers in this assay, from the lowest: compounds 3 and 2 (each within the scatter of the next); then compound 1; then compound 4.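

In this assay, changing 1-(propanoyloxy)ethyl to 1-hydroxyethyl gives a number 11.1 percentage points higher from compound 1 to compound 4 (beyond the scatter) and so shows that, with the ethyl esters of compound 1 in place, the propanoyl is not needed for oral bioavailability in the dog. The free hydroxy group does not by itself hold the number down in compound 4, while compounds 2 and 3 also differ elsewhere and cannot be compared with it directly. Nothing measured here explains this step.

From the compounds shown here alone, whether a smaller acyl group such as acetyl, a longer chain such as butanoyl, or an amine-bearing aminoacetyl on this oxygen would keep the higher number stays open. Going by these compounds, it also stays open whether the same change acts alike when a carboxylic acid stands in place of the ethyl esters.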